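Swapping an Amide for a Urea: What Compound 4 May Give

This account rests on a few compounds, and the source may have more. Where it says the series, first, only, none or still open, it means among the compounds named here.

Compound 1 `COc1cc(-c2nn(-c3cccc(NC(=O)c4ccc(Cl)c(C(F)(F)F)c4)c3)cc2-c2ccncc2)ccc1Cl` gives 20400 nM in a functional assay on TK-10 cells (Homo sapiens) for inhibition, read by sulforhodamine B assay, with a stated time of 48 h (a lower number here means a stronger inhibitor of growth, a higher number a weaker inhibitor of growth), the highest of the three numbers measured. Compound 2 `O=C(Nc1cccc(-n2cc(-c3ccncc3)c(-c3ccc(Cl)c(O)c3)n2)c1)Nc1cccc(C(F)(F)F)c1` gives 2120 nM and compound 3 `O=C(Nc1cccc(-n2cc(-c3ccncc3)c(-c3ccc(Cl)c(O)c3)n2)c1)Nc1ccc(Cl)c(C(F)(F)F)c1` gives 1500 nM; the step of a 1.4-fold lower number from compound 2 to compound 3 (0.15 log units; within the scatter) stays within the scatter, so these two cannot be ranked. Compound 4 `COc1cc(-c2nn(-c3cccc(NC(=O)Nc4ccc(Cl)c(Cl)c4)c3)cc2-c2ccncc2)ccc1Cl` differs from compound 1 by (3,4-dichlorophenyl)amino in place of 4-chloro-3-(trifluoromethyl)phenyl on a carbonyl carbon. Going by the values given here, no measured step covers this change: compounds 2 and 3 do carry a urea like compound 4, but they differ from compound 1 in more than one place, so their lower numbers cannot be tied to the urea alone. The step is therefore expected to be a 2.9-fold lower number from compound 1 to compound 4 (0.46 log units; beyond the scatter), leaning toward a lower number with wide uncertainty. Compound 4 is estimated at 7000 nM, within 1500 nM to 30000 nM.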

Compound 4, concentration for 50% growth inhibition: 1430 nM
For compound 4 the middle estimate is 4.9-fold (0.69 log units) above the measured one; the whole stated range lies above it.
By their numbers in this assay, from the lowest: compounds 4, 3 and 2 (each within the scatter of the next); then compound 1.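

In this assay, the step shows that this place on the carbonyl carbon strongly affects the number on the core of compound 1: a 14-fold lower number from compound 1 to compound 4 (1.15 log units; beyond the scatter). The change brings in an amide-type nitrogen and also replaces the trifluoromethyl with a chloro, so the step holds both changes together. Nothing measured here explains the drop.

The compounds shown leave open how much of the step belongs to the nitrogen and how much to the chloro. They also leave open what a phenyl ring carrying a carboxylic acid would give at this place.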